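The compounds below may be only part of what the source reports. "The series", "measured", "known", "first", "only" and "open" are said of these compounds alone.

Measured compounds:
- compound 1 `COc1ccccc1CN1CCN(c2ccc(C(=O)NS(=O)(=O)c3ccc(N[C@H](CCN(C)C)CSc4ccccc4)c([N+](=O)[O-])c3)cc2)CC1` — 3.2 nM
- compound 2 `CN(C)CC[C@H](CSc1ccccc1)Nc1ccc(S(=O)(=O)NC(=O)c2ccc(N3CCN(Cc4ccccc4S(C)(=O)=O)CC3)cc2)cc1[N+](=O)[O-]` — 4.6 nM
- compound 3 `CN(C)CC[C@H](CSc1ccccc1)Nc1ccc(S(=O)(=O)NC(=O)c2ccc(N3CCN(Cc4ccccc4C(F)(F)F)CC3)cc2)cc1[N+](=O)[O-]` — < 1 nM

In an assay on isolated protein for displacement of a labelled ligand from Apoptosis regulator Bcl-2 (Homo sapiens), read by fluorescence polarization (on this read-out lower numbers stand for stronger inhibition and higher numbers for weaker inhibition), compound 1 gives 3.2 nM and compound 2 gives 4.6 nM; the step of a 1.4-fold higher number from compound 1 to compound 2 (0.16 log units; within the scatter) lies within the scatter. Compound 3 stands apart: its result in this assay is a limit, not a number, since it sits at the limit (the limit of < 1 nM in this assay, at which 1 of the 3 values shown sits). The steps of an at least 3.2-fold lower number from compound 1 to compound 3 (0.50 log units; beyond the scatter) and an at least 4.6-fold lower number from compound 2 to compound 3 (0.66 log units; beyond the scatter) are therefore both at least modest and both run toward stronger binding.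

Compound 4 `CN(C)CC[C@H](CSc1ccccc1)Nc1ccc(S(=O)(=O)NC(=O)c2ccc(N3CCN(Cc4ccccc4-c4cccnc4)CC3)cc2)cc1[N+](=O)[O-]` is not yet measured. It differs from compound 3 by pyridin-3-yl in place of trifluoromethyl on an aromatic carbon. For the measured compounds named here, none of the measured steps replaces the trifluoromethyl with a ring, so the three steps bear on it only loosely: they show that methoxy and methylsulfonyl at this position leave binding in the low single-digit range, while trifluoromethyl pushes it past the limit. Compound 4 is therefore expected to come back above the limit and near compounds 1 and 2, with an expected step of an at least 3.0-fold higher number from compound 3 to compound 4 (0.47 log units; beyond the scatter) toward weaker binding. The estimate for compound 4 in this assay is 3 nM, between 0.7 nM and 15 nM.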

Compound 4, inhibition constant: 1 nM
Estimate against measurement, compound 4: 3.0-fold (0.48 log units) above, and the stated range covers the measured number.
By their numbers in this assay, from the lowest: compound 4; then compounds 1 and 2 (each within the scatter of the next).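

In this assay, the place on an aromatic carbon ortho to a large group accepts a whole six-membered aromatic ring, and pyridin-3-yl binds more strongly than two of the earlier groups: a 4.6-fold lower number from compound 2 to compound 4 (0.66 log units; beyond the scatter) and a 3.2-fold lower number from compound 1 to compound 4 (0.51 log units; beyond the scatter). Earlier compounds carried only non-ring groups here, so a ring with a hydrogen-bond acceptor is the new finding, and it does not return binding to the level of compounds 1 and 2. The third new step gives a direction but no size (a number no lower from compound 3 to compound 4 (the limit leaves the size open)). Compound 3 has a limit rather than a number: the limit of < 1 nM in this assay, at which 1 of the 4 values shown sits.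

On these data alone, it remains open whether the ring nitrogen matters, which a plain phenyl or a pyridin-4-yl at this place would test. Also open, as far as these compounds go, is how a ring carrying an amine or a carboxylic acid would behave here.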